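Chromene chalcone series: aryl swap on the alkene carbon

The source may hold more compounds than are shown below. What is called first, only, known or untested is meant among the compounds shown, and "the series" means these compounds.

The shared core carries a methoxy-substituted chromene on the carbonyl side and a variable aryl ring on the alkene. In a functional assay on K562 cells (Homo sapiens) for antiproliferative activity, read by MTT assay, with a stated time of 24 h (on this read-out higher numbers stand for weaker inhibition and lower numbers for stronger inhibition), compound 1 `COc1ccc(/C=C/C(=O)c2ccc(OC)c3c2OC(C)(C)C=C3)c(F)c1` gives only a limit of the assay, > 10000 nM, so its position among the numbers is known no further than that; this is the limit of > 10000 nM in this assay, at which 1 of the 2 values shown sits. Going by the values given here, compound 2 `COc1ccc(C(=O)/C=C/c2ccc3ccccc3c2)c2c1C=CC(C)(C)O2`, with a naphthyl ring on the same chain carbon, gives 3670 nM in this assay, which is the one numbered value in the set.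

Compound 3 `COc1ccc(C(=O)/C=C/c2cccc([N+](=O)[O-])c2)c2c1C=CC(C)(C)O2` is not yet measured. Relative to compound 1 the change is 3-nitrophenyl in place of 2-fluoro-4-methoxyphenyl on a double-bonded chain carbon bound to a double-bonded chain carbon; in words, 3-nitrophenyl in place of 2-fluoro-4-methoxyphenyl on a double-bonded chain carbon bound to a double-bonded chain carbon. Among the compounds with values here, no measured pair isolates this change, and compound 1 itself offers only a limit, so the expectation rests on the spread seen between compound 1 and compound 2. A step toward stronger inhibition of an at least 1.6-fold lower number from compound 1 to compound 3 (0.22 log units; that floor lies within the scatter) is expected for compound 3 in this assay, though it may well stay within the scatter or return another limit. Compound 3 is estimated at 6000 nM, with a range from 1500 nM to 20000 nM.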

Compound 3, half-maximal inhibitory concentration: 5870 nM
The estimate for compound 3 lay 1.0-fold (0.01 log units) above the measured number, and the stated range covers the measured number.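

In this assay compound 3 gives 5870 nM, a number and not a limit, so a singly substituted phenyl ring on a double-bonded chain carbon bound to a double-bonded chain carbon can return a readable value, which until now had come only from the naphthyl ring of compound 2. Putting 3-nitrophenyl in place of 2-fluoro-4-methoxyphenyl gives an at least 1.7-fold lower number from compound 1 to compound 3 (0.23 log units; that floor lies within the scatter), so this first step at the position has only a floor, and that floor alone does not separate the two compounds. The true size of the step stays unknown, as compound 1 remains a limit: the limit of > 10000 nM in this assay, at which 1 of the 3 values shown sits.

The change removes the fluoro and methoxy groups and brings in the nitro group all at once, so the compounds shown leave open which of these carries the step, and whether the nitro group would read the same elsewhere on the phenyl ring. As far as these compounds go, how an amine or a carboxylic acid on the phenyl ring at this chain carbon would compare with 3-nitrophenyl also stays open.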